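The compounds below may be only part of what the source reports. "The series", "measured", "known", "first", "only" and "open" are said of these compounds alone.

Compound 1 `Cc1cc(OCC2=NCCO2)ccc1Cl`: 30%
Compound 2 `Cc1cccc(OCC2=NCCO2)c1`: 20%

In a toxicity assay on the whole organism with Rattus norvegicus as the target, at a dose of 200 mg/kg by the oral route (a higher number here means a stronger effect of the compound at the dose given, a lower number a weaker effect), compound 2 stands level with compound 1, since the step of a number 10 percentage points lower from compound 1 to compound 2 (within the scatter) lies within the scatter; nothing here separates the two. Compound 3 `O=[N+]([O-])c1cccc(OCC2=NCCO2)c1` differs from compound 2 in one place: nitro in place of methyl on an aromatic carbon. Within the data shown here, no measured step exchanges methyl for nitro, and the single step known, from chloro to hydrogen, produced no change beyond the scatter. A step of a number 2 percentage points higher from compound 2 to compound 3 (within the scatter) is therefore expected, with no clear direction. Compound 3 is estimated at 22%, within a range from 5% to 45%.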

Compound 3, a percentage reported as activity, at one dose (the size of the read-out at that dose, not a potency): 30%
Beside the measured number, compound 3's estimate is 8 percentage points below it; low and high end bracket the measured number.
By their numbers in this assay, from the lowest: compounds 2, 1 and 3 (each within the scatter of the next).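

Replacing methyl with nitro on the aromatic carbon meta to a group of 7 heavy atoms gives a number 10 percentage points higher from compound 2 to compound 3 (within the scatter) in this assay and is the first change shown at this position. Nitro brings more heavy atoms and hydrogen-bond acceptors than methyl, yet the step does not separate the two compounds. No available evidence bears on this result. As far as these compounds go, whether an amine or a carboxylic acid at this position would give a step beyond the scatter remains open. So does whether a longer chain there would do so.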